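This account rests on a few compounds, and the source may have more. Where it says the series, first, only, none or still open, it means among the compounds named here.

Two sulfonamides of the shared core have been tested in a functional assay on KB cells (Homo sapiens) for antiproliferative activity, read by sulforhodamine B assay, with a stated time of 48 h; on this read-out higher numbers stand for weaker inhibition of growth and lower numbers for stronger inhibition of growth. Compound 1 (`Nc1ccccc1NC(=O)c1ccc(CCc2ccccc2NS(=O)(=O)c2ccccc2)cc1`) gives 456 nM, and compound 2 (`Nc1ccccc1NC(=O)c1ccc(CCc2ccccc2NS(=O)(=O)c2ccc(Cl)cc2)cc1`), with chloro in place of hydrogen on an aromatic carbon, gives 448 nM. The two values cannot be told apart, so compound 2 stands level with compound 1 and not clearly ahead of it. The next compound is compound 3 (`Nc1ccccc1NC(=O)c1ccc(CCc2ccccc2NS(=O)(=O)c2ccc(Br)cc2)cc1`), which carries bromo in place of chloro on an aromatic carbon, para to a large group (bromo in place of chloro on an aromatic carbon). For the measured compounds named here, no bromo compound has yet been measured in this assay, so only one measured step bears on this change. That step, a 1.0-fold lower number from compound 1 to compound 2 (0.01 log units; within the scatter), introduced the chloro at the same place and left the number within the scatter. If adding the chloro made no visible difference, exchanging it for bromo offers no ground to expect a shift in either direction. The expected change is therefore no more than a 1.0-fold higher number from compound 2 to compound 3 (0.00 log units; within the scatter), which lies within the scatter. The estimate for compound 3 is 450 nM, with an expected range of 230 nM to 880 nM.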

Compound 3, concentration for 50% growth inhibition: 124 nM
Compound 3: the middle estimate sits 3.6-fold (0.56 log units) above what was measured, and the stated range ends above it.
By their numbers in this assay, from the lowest: compound 3; then compounds 2 and 1 (each within the scatter of the next).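

In this assay this place on the sulfonyl-bound aromatic ring no longer looks indifferent: the exchange of chloro for bromo gives a 3.6-fold lower number from compound 2 to compound 3 (0.56 log units; beyond the scatter), and bromo in place of hydrogen gives a 3.7-fold lower number from compound 1 to compound 3 (0.57 log units; beyond the scatter). The earlier pair had shown only that chloro and hydrogen could not be told apart here, so the new result shows that the number can respond to the group at this place and that the two halogens do not act alike, although the step remains modest. Nothing measured here accounts for the separation of bromo from chloro, so the reason for it stays unknown.

The three compounds leave open whether this lower number belongs to bromo alone or would also appear with other groups at the same place, such as iodo, methyl, methoxy or trifluoromethyl. They also leave open whether bromo would give a similar step on another carbon of that ring, or whether the step would hold on a core with a different link than the present chain.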